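From Chloro to Trifluoromethyl: Estimating Compound 4

This account rests on a few compounds, and the source may have more. Where it says the series, first, only, none or still open, it means among the compounds named here.

Measured so far:
Compound 1 `CC(O)(C(=O)Nc1ccc(S(=O)(=O)c2ccccc2)c(C#N)c1)C(F)(F)F`: in a functional assay (Cavia porcellus) with sulfonylurea receptors; K-ATP channels (Homo sapiens) as the target (on this read-out lower numbers stand for stronger inhibition and higher numbers for weaker inhibition), compound 1 gives 3800 nM.
Compound 2 `COc1cc(NC(=O)C(C)(O)C(F)(F)F)ccc1S(=O)(=O)c1ccccc1`: in this assay compound 2 gives 5900 nM.
Compound 3 `CC(O)(C(=O)Nc1ccc(S(=O)(=O)c2ccccc2)c(Cl)c1)C(F)(F)F`: in this assay compound 3 gives 2200 nM.

The three compounds share one core and differ only in a single group on an aromatic carbon. Compound 3 carries the lowest of the three numbers, but its gap to compound 1 is small: a 1.7-fold lower number from compound 1 to compound 3 (0.24 log units; within the scatter). Its gap to compound 2 is larger: a 2.7-fold lower number from compound 2 to compound 3 (0.43 log units; beyond the scatter), while between the other two a 1.6-fold higher number from compound 1 to compound 2 (0.19 log units; within the scatter). Compound 4 `CC(O)(C(=O)Nc1ccc(S(=O)(=O)c2ccccc2)c(C(F)(F)F)c1)C(F)(F)F` changes that same group once more: trifluoromethyl in place of chloro on an aromatic carbon. Going by the values given here, none of the measured steps involves a trifluoromethyl group, so no step speaks directly to this change; what they do show is that exchanging the group at this place moved the number only modestly in every case, with a gap beyond the scatter seen only from compound 2 to compound 3. The expectation is therefore a small step at most, in either direction, for a 1.1-fold higher number from compound 3 to compound 4 (0.06 log units; within the scatter). Compound 4 is estimated to give 2500 nM in this assay, with a likely range from 900 nM to 7000 nM.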

Compound 4, half-maximal inhibitory concentration: > 30000 nM
Compound 4: a limit, no number; the forecaster's own chance of this, stated with the estimate: 5%; at least 12-fold (1.07 log units) between middle value and limit.
By their numbers in this assay, from the lowest: compounds 3, 1 and 2 (each within the scatter of the next, the first and the last beyond it). At a limit, above all of these: compound 4.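

In this assay compound 4 gives no number but a limit, and it is the only compound shown that does: the limit of > 30000 nM in this assay, at which 1 of the 4 values shown sits.
Going by these compounds alone, the earlier exchanges at this aromatic carbon gave modest steps at most, whereas trifluoromethyl in place of chloro, which swaps 1 heavy atom for 4, gives an at least 13-fold higher number from compound 3 to compound 4 (1.13 log units; beyond the scatter) and is the first large step at this place.
Compared with the other two groups the picture is the same, with an at least 5.0-fold higher number from compound 2 to compound 4 (0.70 log units; beyond the scatter) against methoxy and an at least 7.8-fold higher number from compound 1 to compound 4 (0.89 log units; beyond the scatter) against cyano, so chloro, cyano and methoxy all give measured numbers in a fairly narrow band while trifluoromethyl falls clearly outside it, showing that this position is far less forgiving than the first three compounds suggested.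

As far as these compounds go, how far beyond the limit compound 4 really lies stays open, so the true size of these three steps is unknown and only their lower end can be read. Also open, from the compounds shown here alone, is how other groups would behave at this same place, such as methyl, ethyl or an amine, and so whether the sharp change belongs to trifluoromethyl alone or extends to other groups as well.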